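The compounds below may be only part of what the source reports. "The series", "measured", "known", "first", "only" and "open" are said of these compounds alone.

The compounds measured so far, with their values in an assay on isolated protein for inhibition of Dipeptidyl peptidase 9 (Homo sapiens); on this read-out lower numbers stand for stronger inhibition and higher numbers for weaker inhibition:

Compound 1, `Cc1ccnc(Nc2cc(N3CCC[C@@H](N)C3)nc3ccnn23)c1`, gives > 100000 nM, a limit of the assay and not a number.
Compound 2, `Clc1ccc(Nc2cc(N3CCNCC3)nc3ccnn23)c(Cl)c1`, gives > 100000 nM, likewise a limit and not a number.
Compound 3, `N[C@@H]1CCCN(c2cc(NCc3ccc(Cl)cc3Cl)n3nccc3n2)C1`, gives > 100000 nM, again a limit and not a number.

Compound 2 therefore stands nowhere that can be ranked: only a limit is known for it, and the two other values shown are limits as well. For the measured compounds named here, all three sit at the limit of > 100000 nM in this assay, at which 3 of the 3 values shown sit, so no step between measured compounds can be counted, and nothing in these numbers tells whether any of the three differs from another.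

Compound 4, `Fc1ccc(Nc2cc(N3CCNCC3)nc3ccnn23)c(F)c1`, has not yet been measured in this assay. It differs from compound 2 in one place: 2,4-difluorophenyl in place of 2,4-dichlorophenyl on a nitrogen on an aromatic ring.

Because compound 2 sits at the limit of > 100000 nM in this assay, at which 3 of the 3 values shown sit, the expectation for compound 4 is that the change moves nothing beyond the scatter; the step is estimated as a number no higher from compound 2 to compound 4 (the limit leaves the size open). Compound 4 is expected to give about 100000 nM in this assay, within a range from 30000 nM to 300000 nM, most likely reported again as a limit rather than a number.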

Compound 4, half-maximal inhibitory concentration: > 100000 nM
Compound 4: no number, only a limit; the forecaster's own chance of this, stated with the estimate: 85%; the middle value sits exactly at the limit.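

In this assay compound 4 gives > 100000 nM, a limit of the assay and not a number. For the compounds shown here, compound 2 also carries only a limit, so no step between compound 2 and compound 4 can be read. The compounds shown leave open whether any of them differs from another, since every value shown is the same limit: the limit of > 100000 nM in this assay, at which 4 of the 4 values shown sit.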